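Cytotoxicity Outlook for a Phenethylcarbonyl Analogue

A few compounds are considered here, and "the series" means these few. Any claim that something is new, unique, unknown or untested is made for them only; others in the source may bear on it.

Compound 1, `Cc1ccc(-c2c3c(nc(C)c2[C@H](OC(C)(C)C)C(=O)O)CCN(c2ccc(-c4ccccc4)cc2)C3)cc1`: > 40000 nM
Compound 2, `Cc1ccc(-c2c3c(nc(C)c2C(OC(C)(C)C)C(=O)O)CCN(C)C3)cc1`: > 40000 nM

In an ADME assay on MT2 cells (Homo sapiens) for cytotoxicity, read by XTT assay, with a stated time of 4 days (on this read-out lower numbers stand for higher toxicity in this test and higher numbers for lower toxicity in this test), compound 1 gives > 40000 nM, which is a limit of the assay rather than a number. Compound 2 likewise reaches only > 40000 nM, again a limit. Both measured compounds thus sit at the limit of > 40000 nM in this assay, at which 2 of the 2 values shown sit. Compound 3, `Cc1ccc(-c2c3c(nc(C)c2[C@H](OC(C)(C)C)C(=O)O)CCN(C(=O)CCc2ccccc2)C3)cc1`, differs from compound 1 by phenethylcarbonyl in place of 4-phenylphenyl on an amine nitrogen in a ring. Going by the values given here, no step between measured compounds is available to lean on. Compound 3 is expected to remain at the same limit, so a number no higher from compound 1 to compound 3 (the limit leaves the size open) is estimated as no change beyond the scatter. Compound 3 is therefore estimated at 40000 nM, within 20000 nM to 80000 nM.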

Compound 3, half-maximal cytotoxic concentration: > 40000 nM
Compound 3 gave a limit, no number; the forecaster's own chance of this, stated with the estimate: 85%; the middle value sits exactly at the limit.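

Going by these compounds alone, compound 1 and compound 3 each give only a limit of the assay, not a number, so no step between them can be read. What stays open is whether swapping these groups changes the result in this assay at all, since all the values shown stop at one point: the limit of > 40000 nM in this assay, at which 3 of the 3 values shown sit.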